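This account rests on a few compounds, and the source may have more. Where it says the series, first, only, none or still open, it means among the compounds named here.

Compound 1 `c1ccc(CCCN2CCN(CCN(Cc3ccccc3)c3ccccn3)CC2)cc1`: 6.91
Compound 2 `COc1ccc(N(CCN2CCN(CCCc3ccccc3)CC2)Cc2ccccc2)cc1`: 6.67

Going by the values given here, compound 1 stands highest of the two numbers in an assay on HEK293 cells for inhibition of sodium-dependent dopamine transporter (Homo sapiens); a higher number here means a more potent compound, by a factor of ten per unit of this negative logarithm, a lower number a less potent compound; the one measured step is a number 0.24 log units lower from compound 1 to compound 2 (within the scatter), a change of a different kind. Compound 3 `COc1ccc(CN(CCN2CCN(CCCc3ccccc3)CC2)c2ccccn2)cc1` differs from compound 1 by methoxy in place of hydrogen on an aromatic carbon. Among the compounds with values here, no measured step covers this methoxy addition, and the single known step sits within the scatter. A move of about the same size, or none beyond the scatter, is expected, as a step of a number 0.11 log units lower from compound 1 to compound 3 (within the scatter). Compound 3 is therefore estimated at 6.8, within 6.3 to 7.3.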

Compound 3, logarithm of the reciprocal of the active concentration, log(1/C): 6.57
For compound 3 the middle estimate is 0.23 log units above the measured one; the measured number falls inside the stated range.
By their numbers in this assay, from the lowest: compounds 3, 2 and 1 (each within the scatter of the next, the first and the last beyond it).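

Turning benzyl into 4-methoxybenzyl gives a number 0.34 log units lower from compound 1 to compound 3 (beyond the scatter) in this assay, the first step among these compounds that lies beyond the scatter. This position on the ring therefore responds to substitution, although the change is modest and in the direction of lower potency. Nothing available explains this drop. Going by these compounds, whether a fluorine atom, a hydroxy group or an ethoxy group at this same place would give a similar number remains open. So does whether a methoxy group elsewhere on this ring would give a similar step.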